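Notes on alkyl chain extension across three measured compounds

A few compounds are considered here, and "the series" means these few. Any claim that something is new, unique, unknown or untested is made for them only; others in the source may bear on it.

In a functional assay on A549 cells (Homo sapiens) for inhibition, read by MTT assay, with a stated time of 24 h (a higher number here means a weaker inhibitor, a lower number a stronger inhibitor), compound 1 `CCc1cc2ccccc2nc1-c1cc(-c2ccc(F)cc2)no1` reaches only a limit of the assay, > 100000 nM. Compound 2 `CCCc1cc2ccccc2nc1-c1cc(-c2ccc(F)cc2)no1` gives 51300 nM in this assay. Compound 3 `CCCc1cc2ccccc2nc1-c1cc(-c2ccc(C)cc2)no1` likewise reaches only a limit, > 100000 nM. The change from compound 1 to compound 2 is methyl in place of hydrogen on a saturated chain carbon, two bonds along the chain from an aromatic carbon and it gave an at least 1.9-fold lower number from compound 1 to compound 2 (0.28 log units; that floor lies within the scatter). The next step gave an at least 1.9-fold higher number from compound 2 to compound 3 (0.28 log units; that floor lies within the scatter). The difference between the cores of compound 1 and compound 3 is not broken down here. Compound 4 `CCCCc1cc2ccccc2nc1-c1cc(-c2ccc(C)cc2)no1` is not yet measured; its change from compound 3 is methyl in place of hydrogen on a saturated chain carbon, three bonds along the chain from an aromatic carbon, the same kind of change as from compound 1 to compound 2, though the place differs: two bonds along the chain from an aromatic carbon there, three bonds along the chain here. Given (the limit of > 100000 nM in this assay, at which 2 of the 3 values shown sit), the step is expected to be an at least 1.1-fold lower number from compound 3 to compound 4 (0.04 log units; that floor lies within the scatter), resting on an at least 1.9-fold lower number from compound 1 to compound 2 (0.28 log units; that floor lies within the scatter). Compound 4 is expected near 90000 nM, estimated between 35000 nM and 300000 nM.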

Compound 4, half-maximal inhibitory concentration: > 100000 nM
Compound 4 ended at the assay's limit; the forecaster's own chance of this, stated with the estimate: 55%; middle value at least 1.1-fold (0.04 log units) from the limit.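

Compound 3 and compound 4 both stand only as limits in this assay, so no step between them can be read: the limit of > 100000 nM in this assay, at which 3 of the 4 values shown sit.

The compounds shown leave open whether propyl to butyl changes the read-out in this assay at all.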